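This account rests on a few compounds, and the source may have more. Where it says the series, first, only, none or still open, it means among the compounds named here.

Compound 1 `CC[C@@H]1C[C@H](C)CC/C=C\[C@@H]2C[C@@]2(C(=O)NS(=O)(=O)C2CC2)NC(=O)[C@@H]2C[C@@H](Oc3ncc(OC)c4ccccc34)CN2C(=O)[C@H]1NC(=O)OC(C)(C)C(F)(F)F` gives 15500 ng.h/mL
Compound 2 `CC[C@@H]1C[C@H](C)CC/C=C\[C@@H]2C[C@@]2(C(=O)NS(=O)(=O)C2(C)CC2)NC(=O)[C@@H]2C[C@@H](Oc3ncc(OC)c4ccccc34)CN2C(=O)[C@H]1NC(=O)OC(C)(C)C(F)(F)F` gives 18800 ng.h/mL

For the measured compounds named here, both values come from an ADME assay on the whole organism (Rattus norvegicus) for pharmacokinetics, with a stated time of 24 h, at a dose of 5 mg/kg by the oral route (a higher number here means more compound in the circulation at the dose given, a lower number less compound in the circulation), and are the only numbers so far. Going by the values given here, compound 2 stands level with compound 1 on these numbers, and the one measured step is a 1.2-fold higher number from compound 1 to compound 2 (0.08 log units; within the scatter) for methyl in place of hydrogen on a saturated ring carbon.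

Compound 3 `CC[C@@H]1C[C@H](C)CC/C=C\[C@@H]2C[C@@]2(C(=O)NS(=O)(=O)C2(C)CC2)NC(=O)[C@@H]2C[C@@H](Oc3ncc(OC)c4ccc(F)cc34)CN2C(=O)[C@H]1NC(=O)OC(C)(C)C(F)(F)F` differs from compound 2 by fluoro in place of hydrogen on an aromatic carbon and shares the rest of its structure. The measured step bears on this change only loosely, since it concerns a different group on a different kind of carbon. Among the compounds with values here, no measured step involves fluoro. Within the data shown here, with a 1.2-fold higher number from compound 1 to compound 2 (0.08 log units; within the scatter) as the sole guide, no change beyond the scatter is expected in this assay and no direction can be favoured. The estimated step is a 1.1-fold lower number from compound 2 to compound 3 (0.04 log units; within the scatter) on this basis. Compound 3 is expected at 17000 ng.h/mL with an estimated range of 8000 ng.h/mL to 34000 ng.h/mL in this reading.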

Compound 3, area under the concentration-time curve: 27800 ng.h/mL
The estimate for compound 3 lay 1.6-fold (0.21 log units) below the measured number, within the range that was stated.
By their numbers in this assay, from the lowest: compounds 1, 2 and 3 (each within the scatter of the next).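

Fluoro in place of hydrogen on an aromatic carbon, on the six-membered aromatic ring of carbon only, gives a 1.5-fold higher number from compound 2 to compound 3 (0.17 log units; within the scatter) in this assay and so leaves the reading within the scatter at this position. For the compounds shown here, this is the first reading at an aromatic carbon, as the earlier step concerned methyl on a saturated ring carbon, and the two single changes seen so far both stay within the scatter. No measurement at hand offers an explanation for this reading, whether of the size of the step or of its direction.

From the compounds shown here alone, with one substituent at one aromatic position, it remains open whether a chloro group, a methoxy group or an amine at the same carbon would also stay within the scatter in this assay or move the number beyond it. Going by these compounds, it also remains open whether fluoro on the other aromatic carbons of this ring would read the same, and whether the same change would hold on a parent without the methyl group from the earlier step.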